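The compounds below may be only part of what the source reports. "The series", "measured", "known", "first", "only" and "open" are said of these compounds alone.

Working notes on the series. The four compounds share one core and differ in the group carried on the far aromatic ring. In a functional assay on Ramos cells (Homo sapiens) for antiproliferative activity, read by CCK-8 assay, with a stated time of 24 h (on this read-out lower numbers stand for stronger inhibition and higher numbers for weaker inhibition), compound 1 `C=CC(=O)Nc1cccc(Nc2nc(Cl)nc(Nc3ccc(OCCOC)cc3)n2)c1` returns "not determined" (no result reported), so no number is available for it. Compound 3 `C=CC(=O)Nc1cccc(Nc2nc(Cl)nc(Nc3ccc(Oc4ccccc4)cc3)n2)c1` gives 12300 nM in this assay. Compound 2 `C=CC(=O)Nc1cccc(Nc2ncnc(Nc3ccc(C(=O)Nc4ccc(C)cn4)cc3)n2)c1` reaches only a limit of this assay, > 100000 nM, and no single number is reported for it. It is the one entry sitting at the limit of > 100000 nM in this assay, at which 1 of the 3 values shown sits. Compound 2 thus stands without a point value among the numbers shown, while compound 3 carries the only finite result. Compound 4 `C=CC(=O)Nc1cccc(Nc2ncnc(Nc3ccc(OC)cc3)n2)c1` is the unmeasured member. The change from compound 2 to compound 4 is methoxy in place of (5-methylpyridin-2-yl)carbamoyl on an aromatic carbon. Within the data shown here, no step between measured compounds is available to anchor the size of this change. With compound 3 at 12300 nM as the only finite point, a shift toward stronger inhibition, beyond the usual scatter, is expected for compound 4, estimated at an at least 2.0-fold lower number from compound 2 to compound 4 (0.30 log units; that floor lies within the scatter). Compound 4 is expected to give about 50000 nM in this assay, within 10000 nM to 200000 nM, with a fair chance that only a limit is reported again.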

Compound 4, half-maximal inhibitory concentration: 90000 nM
Beside the measured number, compound 4's estimate is 1.8-fold (0.26 log units) below it; low and high end bracket the measured number.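

In this assay, the far-ring position now carries a point value at the small end of this change: compound 4 gives 90000 nM. Methoxy in place of (5-methylpyridin-2-yl)carbamoyl on this aromatic carbon reads as an at least 1.1-fold lower number from compound 2 to compound 4 (0.04 log units; that floor lies within the scatter), so removing the larger group with its pyridine ring and amide is not shown to bring a shift beyond the usual scatter. The step has only a floor and its full size stays unknown, because compound 2 is held at a limit of the assay: the limit of > 100000 nM in this assay, at which 1 of the 4 values shown sits.

Compound 3 differs from compound 4 in more than one place, so the compounds shown do not separate the phenoxy group from the other difference in the shared core. From the compounds shown here alone, how an amine or a carboxylic acid at this position would read remains open.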